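Amide substituent variation on the shared core of compound 1

The source may hold more compounds than are shown below. What is called first, only, known or untested is meant among the compounds shown, and "the series" means these compounds.

Three amides on the shared core have been measured in an assay on CHO-K1 cells for displacement of a labelled ligand from prostaglandin E2 receptor EP1 subtype (Homo sapiens); on this read-out lower numbers stand for stronger inhibition and higher numbers for weaker inhibition. Compound 1 `Cc1cc(C(=O)NC(C)C)nn1Cc1cc(Cl)ccc1OCc1ccccc1` gives 126 nM, the second highest number of the three. Its nearest neighbour is compound 2 `Cc1cc(C(=O)Nc2cccc(F)c2)nn1Cc1cc(Cl)ccc1OCc1ccccc1`, which gives 200 nM; the step of a 1.6-fold higher number from compound 1 to compound 2 (0.20 log units; within the scatter) lies within the scatter. Furthest away is compound 3 `Cc1cc(C(=O)Nc2c(F)cccc2F)nn1Cc1cc(Cl)ccc1OCc1ccccc1`, which gives 10 nM; the step of a 13-fold lower number from compound 1 to compound 3 (1.10 log units; beyond the scatter) is large, as is a 20-fold lower number from compound 2 to compound 3 (1.30 log units; beyond the scatter).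

Compound 4 `Cc1cc(C(=O)NCc2cccnc2)nn1Cc1cc(Cl)ccc1OCc1ccccc1` is not yet measured. It differs from compound 1 by (pyridin-3-yl)methyl in place of isopropyl on an amide-type nitrogen. Among the measured compounds shown here, no measured step covers this exact change: the two known steps from compound 1 replace isopropyl with an aryl bonded directly to the amide nitrogen, and they pull in opposite directions, one within the scatter and one large. The group entering in compound 4 is neither isopropyl nor a directly attached aryl, so neither step transfers cleanly. For the measured compounds named here, on the evidence of compound 1 at 126 nM and the small step to compound 2, the expected step is a 1.2-fold higher number from compound 1 to compound 4 (0.08 log units; within the scatter), essentially none beyond the scatter, with wide uncertainty because only one change, that to compound 3 a 13-fold lower number from compound 1 to compound 3 (1.10 log units; beyond the scatter), moved the number far. Compound 4 is therefore estimated at 150 nM, with a range of 40 nM to 600 nM.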

Compound 4, half-maximal inhibitory concentration: 50.1 nM
For compound 4 the middle estimate is 3.0-fold (0.48 log units) above the measured one, within the range that was stated.
By their numbers in this assay, from the lowest: compound 3; then compound 4; then compounds 1 and 2 (each within the scatter of the next).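

In this assay, (pyridin-3-yl)methyl in place of isopropyl on the amide-type nitrogen gives a step beyond the scatter (a 2.5-fold lower number from compound 1 to compound 4 (0.40 log units; beyond the scatter)), so a lower number at this position does not depend on an aryl bonded directly to that nitrogen. The same group also improves on 3-fluorophenyl (a 4.0-fold lower number from compound 2 to compound 4 (0.60 log units; beyond the scatter)) but does not reach 2,6-difluorophenyl (a 5.0-fold higher number from compound 3 to compound 4 (0.70 log units; beyond the scatter)), leaving compound 3 with the lowest number of the four and placing compound 4 in a middle rank that the first three amides did not occupy. Nothing available gives a reason for any of these steps.

The compounds shown do not separate the contribution of the pyridine ring nitrogen from that of the added methylene link, which plain benzyl, (pyridin-2-yl)methyl or (pyridin-4-yl)methyl on the same amide nitrogen would begin to address. Also open, from the compounds shown here alone, is whether a longer chain such as 2-(pyridin-3-yl)ethyl follows compound 4, and whether 2,6-difluorobenzyl would keep the low number of compound 3 (10 nM) once a methylene link is present.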